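The compounds below may be only part of what the source reports. "The series", "measured", "known", "first", "only" and "open" are said of these compounds alone.

Within the data shown here, compound 1 `COc1cc(C2=NN(C(C)=O)C(c3c(Cl)cccc3Cl)O2)cc(OC)c1OC` stands highest of the three numbers measured so far in a functional assay on BGC-823 cells (Homo sapiens) for antiproliferative activity, read by MTT assay, tested at 5 uM (a higher number here means a stronger effect of the compound at the concentration tested, a lower number a weaker effect), where compound 1 gives 15.9%. Compound 2 `COc1cccc(/C=N/NC(=O)c2cc(OC)c(OC)c(OC)c2)c1OC` gives 14.2% in this assay, a number within the scatter of compound 1. Compound 3 `COc1cc(C(=O)N/N=C/c2ccc(Cl)c([N+](=O)[O-])c2)cc(OC)c1OC` gives 2.3% in this assay, a number beyond the scatter below compound 1. Compound 4 `COc1cc(C2=NN(C(C)=O)C(c3ccc(Cl)c([N+](=O)[O-])c3)O2)cc(OC)c1OC` has not been measured; it differs from compound 1 by 4-chloro-3-nitrophenyl in place of 2,6-dichlorophenyl on a saturated ring carbon. Compound 3 carries the same 4-chloro-3-nitrophenyl group on a different core and gives 2.3%, the lowest number seen here. A downward step is therefore expected, a number 7.9 percentage points lower from compound 1 to compound 4 (within the scatter), though the cores differ and the step may still fall within the scatter. Compound 4 is expected to give 8% in this assay, with a range from 0% to 20%.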

Compound 4, a percentage reported as inhibition, at one concentration (the size of the read-out at that concentration, not a potency): 0%
Compound 4: middle estimate off by 8 percentage points, on the high side, within the range that was stated.
By their numbers in this assay, from the lowest: compounds 4 and 3 (each within the scatter of the next); then compounds 2 and 1 (each within the scatter of the next).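

On the shared core, the aryl group on the saturated ring carbon matters: in this assay, 4-chloro-3-nitrophenyl in place of 2,6-dichlorophenyl gives a number 15.9 percentage points lower from compound 1 to compound 4 (beyond the scatter), the first step read at this position. With that change, compound 4 gives 0% at the concentration tested, so this replacement leaves no measurable inhibition. No measurement available here bears on why the number falls.

From the compounds shown here alone, the change replaces the whole substituted ring, so which substituent carries the step stays open. Also open, going by these compounds, is how an unsubstituted phenyl, a 4-methoxyphenyl or a 4-aminophenyl group would read on this carbon.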